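Ortho substituent swap on the anilide ring

This account rests on a few compounds, and the source may have more. Where it says the series, first, only, none or still open, it means among the compounds named here.

Compound 2 `O=C(O)c1ccc(NC(=O)[C@H](C2CCCCC2)n2c(-c3ccc(Cl)cc3)nc3cc(F)c(F)cc32)c(C(F)(F)F)c1` is the stronger of the two measured compounds in an assay on isolated protein for displacement of a labelled ligand from Bile acid receptor (Homo sapiens), read by scintillation proximity assay and radioligand binding; a lower number here means a stronger inhibitor, a higher number a weaker inhibitor: compound 2 gives 8 nM. Compound 1 `O=C(O)c1cccc(NC(=O)C(C2CCCCC2)n2c(-c3ccc(Cl)cc3)nc3cc(F)c(F)cc32)c1` differs from compound 2 in several places. In this assay compound 1 gives 1300 nM, so the two values lie far apart, well beyond the scatter. For the measured compounds named here, no single-change pair has been measured, so the weight of any one substituent is not yet known from the data.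

Compound 3 `COc1cc(C(=O)O)ccc1NC(=O)[C@H](C1CCCCC1)n1c(-c2ccc(Cl)cc2)nc2cc(F)c(F)cc21` is the next compound for this assay. It differs from compound 2 by methoxy in place of trifluoromethyl on an aromatic carbon. Going by the values given here, with no measured analogue of this change, the expectation is a modest loss of potency for compound 3, a step of a 3.1-fold higher number from compound 2 to compound 3 (0.49 log units; beyond the scatter) that may still fall within the scatter. Compound 3 is therefore estimated at 25 nM, with a range from 6 nM to 100 nM.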

Compound 3, half-maximal inhibitory concentration: 740 nM
Compound 3: middle estimate off by 30-fold (1.47 log units), on the low side; the measured number lies above the stated range.
By their numbers in this assay, from the lowest: compound 2; then compounds 3 and 1 (each within the scatter of the next).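

For the compounds shown here, this is the first single-change pair. In this assay, methoxy in place of trifluoromethyl on the aromatic carbon ortho to a large group and meta to a carboxy group gives a 93-fold higher number from compound 2 to compound 3 (1.97 log units; beyond the scatter), a large loss of potency well beyond the scatter, so this position does not treat the two groups alike and the weight of this substituent can now be read directly. The compounds shown offer no measurement that bears on the reason for this difference.

Still open, going by these compounds, is whether the potency of compound 2 is particular to trifluoromethyl or would also be seen with a chlorine atom, a methyl group or a nitrile at this carbon. Also open, on these data alone, is how a plain hydrogen there would read against trifluoromethyl and methoxy.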